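The source may hold more compounds than are shown below. What is called first, only, known or untested is meant among the compounds shown, and "the series" means these compounds.

The shared core is constant through the set; only the substituent on the aromatic nitrogen of the fused five-membered ring changes. Compound 1 `CCCn1ccc2cc(/C(C)=C/C(=O)Nc3ccccc3OCCCC(=O)O)ccc21` gives 190 nM in an assay on Prostate gland for inhibition of steroid 5-alpha-reductase (Rattus norvegicus); a lower number here means a stronger inhibitor, a higher number a weaker inhibitor. Compound 2 `CCCC(C(C)C)n1ccc2cc(/C(C)=C/C(=O)Nc3ccccc3OCCCC(=O)O)ccc21` gives 7.2 nM in this assay, and compound 3 `CCCCC(CC)n1ccc2cc(/C(C)=C/C(=O)Nc3ccccc3OCCCC(=O)O)ccc21` gives 7.1 nM, the lowest of the three numbers, although compound 2 sits within the scatter of it. Both moves away from compound 1 are large: a 26-fold lower number from compound 1 to compound 2 (1.42 log units; beyond the scatter) and a 27-fold lower number from compound 1 to compound 3 (1.43 log units; beyond the scatter). The two larger groups do not separate, a 1.0-fold lower number from compound 2 to compound 3 (0.01 log units; within the scatter).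

Compound 4 `C/C(=C\C(=O)Nc1ccccc1OCCCC(=O)O)c1ccc2c(ccn2Cc2ccccc2C)c1` differs from compound 3 in one place: 2-methylbenzyl in place of 1-ethylpentyl on an aromatic nitrogen. For the measured compounds named here, no measured step exchanges a saturated chain for an aromatic group on that nitrogen. The steps from compound 1 show the number falling sharply once the substituent is larger than propyl, and compound 2 against compound 3 shows two groups of comparable size giving the same number. For compound 4 only a modest step in this assay is therefore expected, a 2.0-fold higher number from compound 3 to compound 4 (0.29 log units; within the scatter). Compound 4 is estimated at 14 nM, with a range from 3.5 nM to 55 nM.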

Compound 4, half-maximal inhibitory concentration: 69 nM
For compound 4 the middle estimate is 4.9-fold (0.69 log units) below the measured one, outside the stated range (above it).
By their numbers in this assay, from the lowest: compounds 3 and 2 (each within the scatter of the next); then compound 4; then compound 1.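

On the aromatic nitrogen, heavy-atom count alone does not set the number in this assay: 2-methylbenzyl, with 8 heavy atoms and one six-membered aromatic ring, stands clearly apart from 1-ethylpentyl with 7 (a 9.7-fold higher number from compound 3 to compound 4 (0.99 log units; beyond the scatter)) and from 1-isopropylbutyl (a 9.6-fold higher number from compound 2 to compound 4 (0.98 log units; beyond the scatter)). The aromatic group still keeps part of the gain over propyl (a 2.8-fold lower number from compound 1 to compound 4 (0.44 log units; beyond the scatter)), placing compound 4 between compound 1 and the pair of branched saturated compounds, compound 2 and compound 3. Nothing measured here accounts for the gap between the aromatic and the branched saturated groups on this nitrogen.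

The compounds shown leave open whether that gap follows the aromatic ring itself or the methyl group on it. An unsubstituted benzyl or a cyclohexylmethyl group on the same nitrogen would separate these two readings.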